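Swapping the Aromatic Group on a Ring Amine Nitrogen

A few compounds are considered here, and "the series" means these few. Any claim that something is new, unique, unknown or untested is made for them only; others in the source may bear on it.

Compound 1 `N#Cc1cnc(N2CCC(C(=O)N3N=CC[C@H]3c3cc(F)cc(F)c3)CC2)cn1`: 99%
Compound 2 `CC(=O)N1CCC(C(=O)N2N=CC[C@H]2c2ccccc2)CC1`: 210%

In an ADME assay on the whole organism (Rattus norvegicus) for pharmacokinetics, at a dose of 2 mg/kg by the oral route (a lower number here means that a smaller share of the oral dose reaches the circulation, a higher number that a larger share of the oral dose reaches the circulation), compound 1 sits at 99% and is the lowest of the two measured compounds, while compound 2 reaches 210% in the same read-out, a gap beyond the scatter. The next compound to be tested is compound 3 `Cc1nnc(N2CCC(C(=O)N3N=CC[C@H]3c3cc(F)cc(F)c3)CC2)o1`, which keeps the core of compound 1 and carries 5-methyl-1,3,4-oxadiazol-2-yl in place of 5-cyanopyrazin-2-yl on an amine nitrogen in a ring. The counted difference between the two structures is 5-methyl-1,3,4-oxadiazol-2-yl in place of 5-cyanopyrazin-2-yl on an amine nitrogen in a ring in full.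

Going by the values given here, no measured pair here isolates a change of this kind, so the data do not show its size directly. In this assay no step beyond the scatter is expected, and neither direction is favoured. The expected change, a number 4 percentage points lower from compound 1 to compound 3 (within the scatter), is therefore small, and the estimate stays anchored on compound 1 at 99% as its nearest measured structure. For compound 3 the estimated value is 95% within an expected range (50% to 150%) that is kept wide.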

Compound 3, oral bioavailability: 130%
Beside the measured number, compound 3's estimate is 35 percentage points below it; the range from low to high includes it.
By their numbers in this assay, from the lowest: compound 1; then compound 3; then compound 2.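

In this assay, going by these compounds alone, the exchange of 5-cyanopyrazin-2-yl for 5-methyl-1,3,4-oxadiazol-2-yl on an amine nitrogen in a ring gives a number 31 percentage points higher from compound 1 to compound 3 (beyond the scatter) and is the only step here that isolates a change at this position, showing that the group held there matters for this read-out while the shared core stays unchanged. The two groups differ in ring size and in the triple bond that leaves with the nitrile, yet they count the same hydrogen-bond donors and acceptors and neither carries a net charge, so the step arises without any difference in those counts. No measurement shown accounts for the step, and the data do not say which feature of the two groups lies behind it.

With one pair at this position, the compounds shown leave open whether the ring size, the loss of the nitrile or the added methyl carries the step. They also leave open how an unsubstituted pyrazine ring or a pyridine ring bearing a nitrile would stand on that same nitrogen in this assay.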